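The source may hold more compounds than are shown below. What is called first, only, known or untested is meant among the compounds shown, and "the series" means these compounds.

In a functional assay on Ehrlich cells (Mus musculus) for cytotoxicity, read by trypan blue exclusion, with a stated time of 2 h, tested at 25 ug/mL (a higher number here means a weaker effect of the compound at the concentration tested, a lower number a stronger effect), compound 1 `N#Cc1c(N)[n+]([O-])c2ccc(Cl)cc2[n+]1[O-]` gives 95% and compound 2 `CNc1c(C#N)[n+]([O-])c2cc(Cl)ccc2[n+]1[O-]` gives 94%; the two numbers lie within the scatter of each other, as the step of a number 1 percentage points lower from compound 1 to compound 2 (within the scatter) shows. Compound 3 `CC(=O)N(C(C)=O)c1c(C#N)[n+]([O-])c2cc(Cl)ccc2[n+]1[O-]` differs from compound 2 by diacetylamino in place of methylamino on an aromatic carbon. Within the data shown here, the only measured step that bears on this, a change at the same nitrogen, is a number 1 percentage points lower from compound 1 to compound 2 (within the scatter), so no step beyond the scatter is expected. Compound 3 is therefore expected to give 92% in this assay, within the range 80% to 100%. The expected step is a number 2 percentage points lower from compound 2 to compound 3 (within the scatter).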

Compound 3, a percentage reported as activity, at one concentration (the size of the read-out at that concentration, not a potency): 80.7%
Compound 3: the middle estimate sits 11.3 percentage points above what was measured, within the range that was stated.
By their numbers in this assay, from the lowest: compound 3; then compounds 2 and 1 (each within the scatter of the next).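

At this aromatic carbon, next to the ring nitrogen and ortho to a cyano group, the substituent can move the read-out beyond the scatter in this assay: diacetylamino in place of methylamino gives a number 13.3 percentage points lower from compound 2 to compound 3 (beyond the scatter), and diacetylamino in place of amino gives a number 14.3 percentage points lower from compound 1 to compound 3 (beyond the scatter). The position thus responds to this change with a modestly stronger effect at the concentration tested, which the step from amino to methylamino did not reveal. Nothing measured here explains the step. The compounds shown leave open whether a single acetyl group, as acetylamino, would suffice, and how a longer acyl chain such as dipropionylamino or a cyclic amine such as morpholine would compare.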